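The source may report more compounds than this note shows. Statements on the series, on what has been measured and on what is new or still open speak of the compounds shown alone.

Compound 1 `CCCCCC1(O)C(=O)Nc2ccc(Nc3ccc(C)cc3)cc21`: in a functional assay on NCI-H460 cells (Homo sapiens) for antiproliferative activity, read by MTT assay, with a stated time of 48 h (on this read-out lower numbers stand for stronger inhibition and higher numbers for weaker inhibition), compound 1 gives > 100000 nM, which is a limit of the assay and not a number.
Compound 2 `Cc1ccc(Nc2ccc3c(c2)C(O)(CCC(C)C)C(=O)N3)cc1`: in this assay compound 2 gives 22700 nM.
Compound 3 `CCCCCC1(O)C(=O)Nc2ccc(Nc3ccc(F)cc3)cc21`: in this assay compound 3 gives > 100000 nM, again a limit rather than a number.

The change isopropyl in place of propyl on a saturated chain carbon, two bonds along the chain from a saturated ring carbon made a step of an at least 4.4-fold lower number from compound 1 to compound 2 (0.64 log units; beyond the scatter). Because compound 1 sits at the limit of > 100000 nM in this assay, at which 2 of the 3 values shown sit, only a lower bound for that step can be read. The two cores differ by fluoro in place of methyl on an aromatic carbon, and the step that the two limits leave unreadable from compound 1 to compound 3 cannot be sized.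

Compound 4 `CC(C)CCC1(O)C(=O)Nc2ccc(Nc3ccc(F)cc3)cc21` is not yet measured. It differs from compound 3 by isopropyl in place of propyl on a saturated chain carbon, two bonds along the chain from a saturated ring carbon, the same change at the same place as from compound 1 to compound 2. The expected step in this assay is an at least 3.3-fold lower number from compound 3 to compound 4 (0.52 log units; beyond the scatter), resting on the earlier step of an at least 4.4-fold lower number from compound 1 to compound 2 (0.64 log units; beyond the scatter), with uncertainty from the unreadable step to compound 3. Compound 4 is estimated at 30000 nM, likely between 8000 nM and 110000 nM.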

Compound 4, half-maximal inhibitory concentration: 16800 nM
Beside the measured number, compound 4's estimate is 1.8-fold (0.25 log units) above it; the range from low to high includes it.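

The propyl-to-isopropyl change carried over to a second core in this assay, giving an at least 5.9-fold lower number from compound 3 to compound 4 (0.77 log units; beyond the scatter), so the drop seen on the core of compound 1 appeared again. It does not show that the change is worth the same on both cores, since only lower bounds can be read for the two steps: the same change on two cores in this assay, an at least 4.4-fold lower number (0.64 log units; beyond the scatter) from compound 1 to compound 2 and an at least 5.9-fold lower number (0.77 log units; beyond the scatter) from compound 3 to compound 4; the limit leaves it open whether they differ

With isopropyl in place, fluoro in place of methyl gave a 1.4-fold lower number from compound 2 to compound 4 (0.13 log units; within the scatter), so that pair cannot be told apart in this assay.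

On these data alone, whether the same change lowers the number on a third core remains open. So does what a longer chain or a carboxylic acid in place of isopropyl would do in this assay.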